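The compounds below may be only part of what the source reports. "The series", "measured", "known", "first", "only" and "open" are said of these compounds alone.

Compound 1 `COC(=O)C(Nc1cc(NS(=O)(=O)/C=C/c2c(OC)cc(OC)cc2OC)ccc1OC)c1ccccc1` and compound 2 `COC(=O)C(Nc1cc(NS(=O)(=O)/C=C/c2c(OC)cc(OC)cc2OC)ccc1OC)c1ccc(F)cc1` share one core and differ only by fluoro in place of hydrogen on an aromatic carbon. In a functional assay on K562 cells (Homo sapiens) for cytotoxicity, read by trypan blue exclusion, with a stated time of 96 h (on this read-out lower numbers stand for stronger inhibition and higher numbers for weaker inhibition), compound 1 gives 2500 nM. In this assay compound 2 gives 2500 nM, and the step of no change at the digits printed from compound 1 to compound 2 (within the scatter). Compound 3 `COc1cc(OC)c(/C=C/S(=O)(=O)Nc2ccc(OC)c(NC(C(=O)O)c3ccccc3)c2)c(OC)c1` differs from compound 1 by hydrogen in place of methyl on an oxygen next to a carbonyl group. In this assay compound 3 gives 300 nM, and the step of an 8.3-fold lower number from compound 1 to compound 3 (0.92 log units; beyond the scatter). Compound 2 stands in the same relation to compound 3, the step being an 8.3-fold lower number from compound 2 to compound 3 (0.92 log units; beyond the scatter). Compound 4 `COc1cc(OC)c(/C=C/S(=O)(=O)Nc2ccc(OC)c(NC(C(=O)O)c3ccc(F)cc3)c2)c(OC)c1` is not yet measured in this assay. Its difference from compound 3 is fluoro in place of hydrogen on an aromatic carbon, the same change as was made from compound 1 to compound 2, and the place on the ring is described in the same words for both pairs. Because no change at the digits printed from compound 1 to compound 2 (within the scatter) showed this change leaving the number where it was, a step of about the same size is expected here, no change at the digits printed from compound 3 to compound 4 (within the scatter). Compound 4 is therefore estimated at 300 nM in this assay, with a range from 150 nM to 600 nM, and the measurement will show whether that holds.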

Compound 4, half-maximal inhibitory concentration in the K562 assay: 20 nM
Estimate against measurement, compound 4: 15-fold (1.18 log units) above, and the stated range ends above it.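

In the K562 assay, the fluoro change did not carry over from one core to the other: a 15-fold lower number from compound 3 to compound 4 (1.18 log units; beyond the scatter) on the carboxy core, which is set against no change at the digits printed from compound 1 to compound 2 (within the scatter) on the methyl ester core: the same change on two cores in the K562 assay, no change at the digits printed (within the scatter) from compound 1 to compound 2 and a 15-fold lower number (1.18 log units; beyond the scatter) from compound 3 to compound 4, 15-fold (1.18 log units) apart, beyond the scatter of two such steps

In the K562 assay, the exchange of methyl for hydrogen on the oxygen also differs between the two pairs, with a 130-fold lower number from compound 2 to compound 4 (2.10 log units; beyond the scatter), and the two changes taken together give a 130-fold lower number from compound 1 to compound 4 (2.10 log units; beyond the scatter): the same change on two cores in the K562 assay, an 8.3-fold lower number (0.92 log units; beyond the scatter) from compound 1 to compound 3 and a 130-fold lower number (2.10 log units; beyond the scatter) from compound 2 to compound 4, 15-fold (1.18 log units) apart, beyond the scatter of two such steps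

Across these four compounds, then, the size of each step depends on the other change, so a step read on one core was no guide to the step on the other, but this does not show why the steps differ or whether the same holds for any compound outside these four.

In a physicochemical assay for solubility (a higher number here means a more soluble compound, a lower number a less soluble compound), compound 3 gives 10000 ug/mL and compound 4 gives 10000 ug/mL.

The compounds shown leave open whether a chlorine atom in place of fluoro, on the same aromatic carbon para to a large group, would give a step like that on the carboxy core. They also leave open whether an amide in place of the carboxylic acid would keep the lower numbers.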